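Amino on the aromatic carbon of compound 1

A few compounds are considered here, and "the series" means these few. Any claim that something is new, unique, unknown or untested is made for them only; others in the source may bear on it.

In a physicochemical assay for solubility, at pH 7.4 (on this read-out higher numbers stand for higher solubility and lower numbers for lower solubility), compound 1 (`NS(=O)(=O)c1ccc(S(=O)(=O)CCCO)cc1`) gives 7200 ug/mL as the second highest of three numbers. Compound 2 (`NS(=O)(=O)c1ccc(S(=O)(=O)CC(O)CO)cc1`) gives 14900 ug/mL and stands above it. Compound 3 (`CC(C)(O)CCSc1ccc(S(N)(=O)=O)cc1`) gives 400 ug/mL and lies furthest from compound 1.

Compound 4 (`Nc1cc(S(N)(=O)=O)ccc1S(=O)(=O)CCCO`) carries one change from compound 1: amino in place of hydrogen on an aromatic carbon in short, amino in place of hydrogen on an aromatic carbon, ortho to a group of 7 heavy atoms and meta to a sulfamoyl group. Going by the values given here, one measured step bears on it, and only loosely (a 2.1-fold higher number from compound 1 to compound 2 (0.32 log units; beyond the scatter)). That step is modest and beyond the scatter, but it is hydroxy in place of hydrogen on a saturated chain carbon. Among the compounds with values here, no measured step covers a change on the aromatic carbon, so the direction remains open. With compound 1 already near the top of the numbers, a modest drop in this assay is the tentative call. The expected step is a 1.8-fold lower number from compound 1 to compound 4 (0.26 log units; within the scatter) and it may not clear the scatter by much. For compound 4 the estimated value is 4000 ug/mL with an expected range from 1300 ug/mL to 11000 ug/mL in this set.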

Compound 4, solubility: 8400 ug/mL
Beside the measured number, compound 4's estimate is 2.1-fold (0.32 log units) below it; low and high end bracket the measured number.
By their numbers in this assay, from the lowest: compound 3; then compounds 1, 4 and 2 (each within the scatter of the next, the first and the last beyond it).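

In this assay amino in place of hydrogen on an aromatic carbon gives a 1.2-fold higher number from compound 1 to compound 4 (0.07 log units; within the scatter) and so leaves the read-out unresolved from that of the core of compound 1 at this position, ortho to a group of 7 heavy atoms and meta to a sulfamoyl group. Going by these compounds alone, this is the first measured change on the aromatic ring, whereas the earlier step of a 2.1-fold higher number from compound 1 to compound 2 (0.32 log units; beyond the scatter) concerns a saturated chain carbon. No measured evidence is available to explain the result.

From the compounds shown here alone, whether a carboxylic acid, a hydroxy group or a dimethylamino group at this aromatic carbon would also stay within the scatter of compound 1 remains open. Also open, going by these compounds, is whether amino at the same position would give a similar step on the chain of compound 2.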